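The compounds below may be only part of what the source reports. "The series", "measured", "known", "first", "only" and "open" are said of these compounds alone.

Working notes on the series. Compound 1 `Cc1cc(Cl)cc(-c2ccnc3cc(CN4C(=O)CCC4=O)sc23)c1CN1CCNC[C@@H]1C` gives 280 nM in an assay on RKO cells for inhibition of ubiquitin carboxyl-terminal hydrolase 7 (Homo sapiens), read by a luciferase reporter, with a stated time of 18 h; a higher number here means that more compound is needed for the effect, a lower number that less compound is needed. Compound 2 `Cc1cc(Cl)cc(-c2ccnc3cc(CN4C(=O)CCC4=O)sc23)c1CN1[C@@H](C)CNC[C@@H]1C` gives 60 nM in this assay. Among the measured compounds shown here, the single measured step so far is a 4.7-fold lower number from compound 1 to compound 2 (0.67 log units; beyond the scatter), and it shows a methyl in place of hydrogen on a saturated ring carbon moving the number beyond the scatter. On these two numbers compound 2 stands lowest, with compound 1 the nearest at a higher number that lies beyond the scatter.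

Compound 3 `Cc1cc(Cl)cc(-c2ccnc3cc(CN4C(=O)CCC4=O)sc23)c1O[C@H]1CCCNC1` is the next case. It differs from compound 2 by (piperidin-3-yl)oxy in place of (2,6-dimethylpiperazin-1-yl)methyl on an aromatic carbon. The change takes away the (2,6-dimethylpiperazin-1-yl)methyl group, including the methyl groups on saturated ring carbons, and puts (piperidin-3-yl)oxy in its place on the aromatic carbon. Only a 4.7-fold lower number from compound 1 to compound 2 (0.67 log units; beyond the scatter) bears on this, and only in part: that step was a gain from one added methyl, so removing the methyl groups together with the change of group is expected to run the other way. The expected step is a 5.0-fold higher number from compound 2 to compound 3 (0.70 log units; beyond the scatter), a higher number, beyond the scatter. Compound 3 is estimated at 300 nM in this assay, with a range from 80 nM to 1500 nM.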

Compound 3, half-maximal effective concentration: 180 nM
Estimate against measurement, compound 3: 1.7-fold (0.22 log units) above, and the stated range covers the measured number.
By their numbers in this assay, from the lowest: compound 2; then compounds 3 and 1 (each within the scatter of the next).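

Among the compounds shown here, this result is the first change at the aromatic carbon ortho to a methyl group and para to a chloro group, as all earlier variation lay within the piperazine ring. In this assay, (piperidin-3-yl)oxy in place of (2,6-dimethylpiperazin-1-yl)methyl gives a 3.0-fold higher number from compound 2 to compound 3 (0.48 log units; beyond the scatter), so the replacement does not keep the number reached with the dimethylpiperazine group, while the comparison with the (2-methylpiperazin-1-yl)methyl group gives a 1.6-fold lower number from compound 1 to compound 3 (0.19 log units; within the scatter), which shows that a ring with 1 hetero atom, joined through oxygen, can stand at this position without a step beyond the scatter from compound 1. No supporting data bear on what lies behind either step.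

For the compounds shown here, it remains open whether a methyl on a saturated ring carbon of the (piperidin-3-yl)oxy group would bring a step like a 4.7-fold lower number from compound 1 to compound 2 (0.67 log units; beyond the scatter), as that gain is so far seen only on the piperazine ring. The compounds shown also leave open how a (pyrrolidin-3-yl)oxy group, a (piperidin-4-yl)oxy group or an open-chain aminoethoxy group would read at this position.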